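Phenyl for 2-hydroxynaphthalen-1-yl: notes on compound 4

The source may hold more compounds than are shown below. What is called first, only, known or untested is meant among the compounds shown, and "the series" means these compounds.

compound 1 `CCCSc1nc(N/N=C/c2cccnc2)c2nnn(Cc3ccccc3)c2n1` gives 58700 nM
compound 2 `CCCSc1nc(N/N=C/c2ccccc2Cl)c2nnn(Cc3ccccc3)c2n1` gives 13800 nM
compound 3 `CCCSc1nc(N/N=C/c2c(O)ccc3ccccc23)c2nnn(Cc3ccccc3)c2n1` gives 6400 nM

These values come from a functional assay on MCF7 cells (Homo sapiens) for antiproliferative activity, read by MTT assay, with a stated time of 72 h (on this read-out higher numbers stand for weaker inhibition and lower numbers for stronger inhibition), and the three compounds differ only in the group on a carbon with a double bond to nitrogen. Compound 3 holds the lowest number of the three, with 6400 nM as its value, and compound 2 stands nearest to it.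

Compound 4 `CCCSc1nc(N/N=C/c2ccccc2)c2nnn(Cc3ccccc3)c2n1` is not yet measured. For the measured compounds named here, it carries phenyl in place of 2-hydroxynaphthalen-1-yl on a carbon with a double bond to nitrogen and no measured compound has that group. The measured steps at this place are a 2.2-fold lower number from compound 2 to compound 3 (0.33 log units; beyond the scatter) and a 9.2-fold lower number from compound 1 to compound 3 (0.96 log units; beyond the scatter) and also a 4.3-fold lower number from compound 1 to compound 2 (0.63 log units; beyond the scatter) and all of them are modest and beyond the scatter. Both compounds without 2-hydroxynaphthalen-1-yl show higher numbers than compound 3. Phenyl is 2-chlorophenyl without its chlorine, but the data hold no step for that removal, so the expectation stays loose. Expected in this assay is a modest move to a higher number, estimated as a 3.1-fold higher number from compound 3 to compound 4 (0.49 log units; beyond the scatter) in the direction of weaker inhibition. The estimate for compound 4 is 20000 nM as the expected value, with an expected range from 8000 nM to 50000 nM on this read-out.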

Compound 4, half-maximal inhibitory concentration: > 64000 nM
Compound 4 ended at the assay's limit (the forecaster's own chance of this, stated with the estimate: 8%); middle value at least 3.2-fold (0.50 log units) from the limit.
By their numbers in this assay, from the lowest: compound 3; then compound 2; then compound 1. At a limit, above all of these: compound 4.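

The value of compound 4 in this assay is a limit of the assay and not a number: the limit of > 64000 nM in this assay, at which 1 of the 4 values shown sits. Unsubstituted phenyl gives the series its first step that removes a single substituent: hydrogen in place of chloro on an aromatic carbon gives an at least 4.6-fold higher number from compound 2 to compound 4 (0.66 log units; beyond the scatter), so the chloro counts in this assay, while phenyl in place of 2-hydroxynaphthalen-1-yl on a carbon with a double bond to nitrogen gives an at least 10-fold higher number from compound 3 to compound 4 (1.00 log units; beyond the scatter). The earlier steps shown here only exchanged one whole aryl group for another, so they could not show that an aromatic ring alone at this place falls short of its substituted forms; phenyl in place of pyridin-3-yl gives an at least 1.0-fold higher number from compound 1 to compound 4 (0.03 log units; that floor lies within the scatter), a step that cannot be read, and the pyridin-3-yl group therefore cannot be ranked against phenyl.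

The compounds shown do not separate the hydroxyl from the second ring within 2-hydroxynaphthalen-1-yl, a question that 2-hydroxyphenyl and unsubstituted naphthalen-1-yl would address. They also leave open whether a group such as bromo, methoxy or an amine could stand in for the chloro, and whether a longer chain on the sulfur would alter any of these steps.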